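Aryl ether to pyridylmethyl ether: half-life outlook

The compounds below may be only part of what the source reports. "The series", "measured", "known", "first", "only" and "open" are said of these compounds alone.

Measured so far:
compound 1 `Nc1ncccc1-c1cc(Cc2ccc(Oc3ccccn3)cc2)no1` gives 1.03 h
compound 2 `Nc1ncccc1-c1cc(Cc2ccc(OCc3ccncc3)cc2)no1` gives 0.288 h
compound 3 `Nc1ncccc1-c1cc(Cc2ccc(Oc3cccc(F)c3)nc2)no1` gives 1.57 h

All three numbers come from an ADME assay on microsomes from liver (Homo sapiens) for metabolic stability, read by LC-MS, using NADPH, with stated times of 5 min and 45 min, tested at 1 uM; a lower number here means that the compound disappears faster, a higher number that the compound lasts longer. Compound 3 holds the highest of the three numbers; compound 1 stands nearest to it, within the scatter, and compound 2 stands furthest from it, beyond the scatter. Compound 4 `Nc1ncccc1-c1cc(Cc2ccc(OCc3ccncc3)nc2)no1` has not yet been measured. It differs from compound 3 in one place: (pyridin-4-yl)methyl in place of 3-fluorophenyl on an oxygen on an aromatic ring. Among the compounds with values here, one measured step bears on this change, since it places the same (pyridin-4-yl)methyl group on the same oxygen in exchange for an aromatic ring: a 3.6-fold lower number from compound 1 to compound 2 (0.55 log units; beyond the scatter). Within the data shown here, that step starts from pyridin-2-yl rather than from 3-fluorophenyl, so the match is not exact, but no other pair speaks to the change. A downward step of comparable size in this assay is therefore expected, beyond the scatter. Compound 4 is expected to give 0.45 h, with a range from 0.2 h to 1 h. This estimate amounts to a 3.5-fold lower number from compound 3 to compound 4 (0.54 log units; beyond the scatter), which is expected to lie beyond the scatter.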

Compound 4, half-life: 0.338 h
For compound 4 the middle estimate is 1.3-fold (0.12 log units) above the measured one, within the range that was stated.
By their numbers in this assay, from the lowest: compounds 2 and 4 (each within the scatter of the next); then compounds 1 and 3 (each within the scatter of the next).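

In this assay, the move to (pyridin-4-yl)methyl on the oxygen gives a 4.6-fold lower number from compound 3 to compound 4 (0.67 log units; beyond the scatter), so the downward step is no longer tied to the core of compound 1 or to pyridin-2-yl as the leaving group. Set beside a 3.6-fold lower number from compound 1 to compound 2 (0.55 log units; beyond the scatter), it gives two steps in the same direction, both beyond the scatter, and no compound shown goes against this; compound 2 and compound 4 also lie within the scatter of each other, even though 3-fluorophenyl and (pyridin-4-yl)methyl both carry 7 heavy atoms, so the step in this pair comes with no change in that count. The data shown offer no explanation for either step.

The compounds shown do not separate the methylene link from the ring nitrogen of the entering group, since both arrive together in each step. On these data alone, a benzyl group or a directly attached pyridin-4-yl group on the same oxygen would pull these two parts apart, and the direction of the step with either group remains open.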